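Changing the aryl group on the ring nitrogen of compound 1

A few compounds are considered here, and "the series" means these few. Any claim that something is new, unique, unknown or untested is made for them only; others in the source may bear on it.

Of the compounds shown here, two have been measured in a functional assay on A549 cells (Homo sapiens) for inhibition, read by sulforhodamine B assay, with a stated time of 48 h, tested at 50 uM; on this read-out higher numbers stand for more inhibition of growth at the one concentration tested and lower numbers for less inhibition of growth. Compound 1 `COc1ccc([C@@H]2C/C(=N/OCc3cn(-c4ccccc4CO)nn3)c3cc(CC=C(C)C)c(OC)cc3O2)cc1` stands highest of the two, giving 100% in this assay. Compound 2 `CCCCOc1ccc([C@@H]2CC(=O)c3cc(CC=C(C)C)c(OC)cc3O2)cc1` differs from it in more than one place and reaches only 37% in this assay, a gap that lies beyond the usual scatter of this measurement.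

Compound 3 `COc1ccc([C@@H]2C/C(=N/OCc3cn(-c4ccc(C(N)=O)cc4)nn3)c3cc(CC=C(C)C)c(OC)cc3O2)cc1` has not yet been measured. It keeps the shared core of compound 1 and changes only the group carried on the aromatic nitrogen: 4-carbamoylphenyl in place of 2-(hydroxymethyl)phenyl on an aromatic nitrogen. The group that leaves and the group that enters are close in size and each carries one hydrogen-bond donor and one hydrogen-bond acceptor.

Among the measured compounds shown here, with no step between measured compounds that isolates this part of the structure, the expectation rests on the position of compound 1 alone, which already sits at full inhibition with 100% in this assay. The step from compound 1 to compound 3 is expected to be small, a number 12 percentage points lower from compound 1 to compound 3 (beyond the scatter). A downward direction is more likely than an upward one because compound 1 already gives 100% in this assay, which leaves no room above. Compound 3 is therefore estimated at 88% in this assay, within a range from 60% to 100%.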

Compound 3, percent growth inhibition at one concentration: 100%
Compound 3: the middle estimate sits 12 percentage points below what was measured; low and high end bracket the measured number.
By their numbers in this assay, from the lowest: compound 2; then compounds 1 and 3 (each within the scatter of the next).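

Among the compounds shown here, on the aromatic nitrogen of the shared core, 4-carbamoylphenyl in place of 2-(hydroxymethyl)phenyl brings no change at the digits printed from compound 1 to compound 3 (within the scatter) in this assay, the first reading that isolates this position. The hydroxymethyl group of compound 1 is therefore not required for this level of growth inhibition, since compound 3 carries a carbamoyl group in its place and at a different point on the phenyl ring. Yet compound 1 and compound 3 both stand at the top of this read-out at the one concentration tested, so the step shows that the position accepts this exchange, but it cannot separate the two compounds any further. Nothing in the data gives a reason for this result.

What the compounds shown leave open is whether any substituent on the phenyl ring matters at all, as a plain phenyl group would test, and how a phenyl ring bearing a carboxylic acid or an amine would behave on this nitrogen. They also leave open whether a saturated group such as a butyl chain could replace the aromatic ring here.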